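Dopamine D4 series: ortho substituent swap on the phenylpiperazine

The compounds below may be only part of what the source reports. "The series", "measured", "known", "first", "only" and "open" are said of these compounds alone.

Measured compounds:
compound 1 `N#Cc1ccccc1N1CCN(Cc2nc3ccccc3[nH]2)CC1` 14.6 nM
compound 2 `N#Cc1cccnc1N1CCN(Cc2nc3ccccc3[nH]2)CC1` 13.9 nM
compound 3 `O=[N+]([O-])c1ccccc1N1CCN(Cc2nc3ccccc3[nH]2)CC1` 3.9 nM

Three compounds share one core and differ only in the group on the aromatic ring attached to the piperazine nitrogen. In an assay on HEK293 cells with D(4) dopamine receptor (Homo sapiens) as the target, read by FLIPR (a lower number here means that less compound is needed, a higher number that more compound is needed for the effect), compound 1 gives 14.6 nM and compound 2 gives 13.9 nM; the step of a 1.1-fold lower number from compound 1 to compound 2 (0.02 log units; within the scatter) shows that the change of ring type leaves the result unchanged. The step of a 3.7-fold lower number from compound 1 to compound 3 (0.57 log units; beyond the scatter) is the only one beyond the scatter, so compound 3 gives the lowest number of the three, set apart from both compounds 1 and 2.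

Compound 4 `CSc1ccccc1N1CCN(Cc2nc3ccccc3[nH]2)CC1` is not yet measured. It differs from compound 3 by methylsulfanyl in place of nitro on an aromatic carbon. Within the data shown here, no measured step covers this pair directly. Among the measured compounds shown here, the only step bearing on it is a 3.7-fold lower number from compound 1 to compound 3 (0.57 log units; beyond the scatter), which shows that exchanging the group at this position can move the number by a modest amount, and the step of a 1.1-fold lower number from compound 1 to compound 2 (0.02 log units; within the scatter) shows that not every change at the ring shifts it. The exact direction for methylsulfanyl is not established. Because compound 3 gives 3.9 nM and the step of a 3.7-fold lower number from compound 1 to compound 3 (0.57 log units; beyond the scatter) is only modest, the working expectation for compound 4 is a modest move back upward, a 3.1-fold higher number from compound 3 to compound 4 (0.49 log units; beyond the scatter), with the estimate being uncertain in direction. Compound 4 is therefore expected to give 12 nM, within the range 3.5 nM to 40 nM.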

Compound 4, half-maximal effective concentration: 86 nM
Compound 4: middle estimate off by 7.2-fold (0.86 log units), on the low side; the measured number lies above the stated range.
By their numbers in this assay, from the lowest: compound 3; then compounds 2 and 1 (each within the scatter of the next); then compound 4.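

Methylsulfanyl in place of nitro on this aromatic carbon gives a 22-fold higher number from compound 3 to compound 4 (1.34 log units; beyond the scatter) in this assay, a large step where the earlier compounds showed only a modest one or none. The same group also separates compound 4 from both nitrile-bearing compounds, with a 5.9-fold higher number from compound 1 to compound 4 (0.77 log units; beyond the scatter) and a 6.2-fold higher number from compound 2 to compound 4 (0.79 log units; beyond the scatter), so compound 4 gives the highest number of the four. The group on this carbon, ortho to a large group, can therefore raise the number from the level of compound 1 as well as lower it, and the span at this place is wider than the first three compounds showed.

Nothing at hand accounts for the size or direction of these steps. The compounds shown leave open where a methoxy group, a chlorine atom or an amino group on this carbon would fall relative to nitro and methylsulfanyl, and whether nitro and methylsulfanyl would keep the same order on the ring of compound 2.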